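Chlorophenyl to Cyanophenyl on the Ring Nitrogen

The source may hold more compounds than are shown below. What is called first, only, known or untested is meant among the compounds shown, and "the series" means these compounds.

Compound 1 `CC1(C)[C@H]2CC[C@]1(C)N(Cc1cn(-c3cccc(Cl)c3)nn1)C(=O)C2`: 510 nM
Compound 2 `CC1(C)[C@H]2CC[C@]1(C)N(Cc1cn(-c3ccc(Cl)cc3)nn1)C(=O)C2`: 410 nM
Compound 3 `CC1(C)[C@H]2CC[C@]1(C)N(Cc1cn(-c3ccccc3C#N)nn1)C(=O)C2`: 260 nM
Compound 4 `CC1(C)[C@H]2CC[C@]1(C)N(Cc1cn(-c3cccc(C#N)c3)nn1)C(=O)C2`: not yet measured

Of the compounds shown here, three sharing one core have been measured in a functional assay on SGC-7901 cells (Homo sapiens) for inhibition, read by MTT assay, with a stated time of 24 h; a lower number here means a stronger inhibitor, a higher number a weaker inhibitor. Compound 2 holds the second highest of the three numbers, yet every gap around it is small: a 1.2-fold lower number from compound 1 to compound 2 (0.09 log units; within the scatter) and a 1.6-fold lower number from compound 2 to compound 3 (0.20 log units; within the scatter) both lie within the scatter, as does a 2.0-fold lower number from compound 1 to compound 3 (0.29 log units; within the scatter). Compound 4 differs from compound 2 by 3-cyanophenyl in place of 4-chlorophenyl on an aromatic nitrogen. Moving the chlorine from the 3- to the 4-position and trading chlorine for a nitrile each left the number within the scatter, so no step beyond the scatter is expected here. The expected step is a 1.2-fold lower number from compound 2 to compound 4 (0.07 log units; within the scatter). Compound 4 is therefore estimated at 350 nM, with a range from 150 nM to 800 nM.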

Compound 4, half-maximal inhibitory concentration: 250 nM
Beside the measured number, compound 4's estimate is 1.4-fold (0.15 log units) above it, within the range that was stated.
By their numbers in this assay, from the lowest: compounds 4, 3, 2 and 1 (each within the scatter of the next, the first and the last beyond it).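

In this assay, replacing the chlorine of the 3-chlorophenyl group with a nitrile gives the only step among these compounds that is beyond the scatter, though a modest one, with a 2.0-fold lower number from compound 1 to compound 4 (0.31 log units; beyond the scatter) for cyano in place of chloro on an aromatic carbon. The other two steps, a 1.6-fold lower number from compound 2 to compound 4 (0.21 log units; within the scatter) and a 1.0-fold lower number from compound 3 to compound 4 (0.02 log units; within the scatter), stay within the scatter, so neither 4-chlorophenyl nor 2-cyanophenyl can be separated from 3-cyanophenyl here. No evidence on hand bears on why the nitrile step arises.

Going by these compounds, it remains open whether a nitrile is special or whether other groups on this phenyl ring, such as an amine or a carboxylic acid, would give a similar number. The compounds shown also leave open how the 4-cyanophenyl group would compare.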